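A few compounds are considered here, and "the series" means these few. Any claim that something is new, unique, unknown or untested is made for them only; others in the source may bear on it.

Compound 1 `N#CC1=C(N)N(c2ccc(S(N)(=O)=O)cc2)C2=C(CCCC2)C1c1cccc([N+](=O)[O-])c1` in a functional assay on Ehrlich cells (Mus musculus) for cytotoxicity, read by trypan blue exclusion, with a stated time of 2 h (on this read-out higher numbers stand for weaker inhibition and lower numbers for stronger inhibition), gives > 100 ug/mL, which is a limit of the assay and not a number.
Compound 2 `N#CC1=C(N)N(c2ccc(S(N)(=O)=O)cc2)C2=C(CCCC2)C1c1ccccc1Cl` in this assay gives > 100 ug/mL, again a limit.
Compound 3 `Cc1ccc(C2C(C#N)=C(N)N(c3ccc(S(N)(=O)=O)cc3)C3=C2CCCC3)o1` in this assay gives > 100 ug/mL, also a limit.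

Compound 3 therefore stands where every measured compound stands: at the limit of > 100 ug/mL in this assay, at which 3 of the 3 values shown sit. For the measured compounds named here, no compound here has a read number, so the steps among them cannot be sized. The step that the two limits leave unreadable from compound 1 to compound 2, the step that the two limits leave unreadable from compound 1 to compound 3 and the step that the two limits leave unreadable from compound 2 to compound 3 all remain unreadable, because each end sits at the limit.

The step to compound 4 `N#CC1=C(N)N(c2ccc(S(N)(=O)=O)cc2)C2=C(CCCC2)C1c1cccs1` changes the group on the saturated ring carbon: thiophen-2-yl in place of 5-methylfuran-2-yl on a saturated ring carbon. Going by the values given here, the only measured step that touches this position in the same way is the exchange of aryl groups on that carbon, and in all three cases the outcome stayed at the limit. The bearing steps thus give no size and no direction; what they show is that three different groups on this carbon, whether carrying a nitro, a chloro or a methyl-bearing furan, left the read-out at the limit.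

For compound 4 the expectation is accordingly a value at or beyond the limit, and the step that the limit leaves unreadable from compound 3 to compound 4 is expected to be none beyond the scatter. Compound 4 is estimated at 150 ug/mL, with a range from 70 ug/mL to 500 ug/mL, and most likely reported once more only as a limit.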

Compound 4, half-maximal inhibitory concentration: > 100 ug/mL
Compound 4 ended at the assay's limit; the forecaster's own chance of this, stated with the estimate: 85%; the middle value is on the limit's open side.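

No new step can be read from compound 4 to compound 1, compound 2 or compound 3, because all four stand at a limit of the assay and not at a number: the limit of > 100 ug/mL in this assay, at which 4 of the 4 values shown sit.

The compounds shown leave open how far each lies beyond that limit, and whether any other group on the saturated ring carbon would give a read number in this assay.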